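Sulfonyl aryl variation: dichloro analogue in the series

A few compounds are considered here, and "the series" means these few. Any claim that something is new, unique, unknown or untested is made for them only; others in the source may bear on it.

The series shares one core, in which the aryl group on the sulfonyl sulfur is varied. Compound 3 `Cc1ccc(S(=O)(=O)c2cnc3cc(F)ccc3c2N2CCC(C)CC2)cc1C` carries a 3,4-dimethylphenyl there; in an assay on isolated protein for displacement of a labelled ligand from metabotropic glutamate receptor 5 (Homo sapiens), with a stated time of 60 min, tested at 1 uM (a higher number here means more inhibition at the concentration tested (going by the name of the read-out), a lower number less inhibition), compound 3 gives 90%. Compound 2 `COc1cccc(S(=O)(=O)c2cnc3cc(F)ccc3c2N2CCC(C)CC2)c1` gives 90% in this assay, and the parent compound 1 `CC1CCN(c2c(S(=O)(=O)c3ccccc3)cnc3cc(F)ccc23)CC1` gives 87%. The three numbers lie within the scatter of one another: a number 3 percentage points higher from compound 1 to compound 2 (within the scatter), a number 3 percentage points higher from compound 1 to compound 3 (within the scatter) and no change at the digits printed from compound 2 to compound 3 (within the scatter), so compound 3 stands level with compound 2 at the digits printed and within the scatter of compound 1.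

The next compound, compound 4 `CC1CCN(c2c(S(=O)(=O)c3cc(Cl)cc(Cl)c3)cnc3cc(F)ccc23)CC1`, differs from compound 3 in one place: 3,5-dichlorophenyl in place of 3,4-dimethylphenyl on a sulfonyl sulfur. Both earlier changes on the sulfonyl sulfur, from phenyl to 3-methoxyphenyl and to 3,4-dimethylphenyl, bear on this step, and neither moved the read-out beyond the scatter. Among the compounds with values here, nothing among the measured compounds distinguishes chlorine from methyl or methoxy on this aryl, so no step beyond the scatter is expected here either; the expected step is a number 4 percentage points lower from compound 3 to compound 4 (within the scatter). Compound 4 is therefore estimated at 86% in this assay, with a range from 70% to 95%.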

Compound 4, a percentage reported as inhibition, at one concentration (the size of the read-out at that concentration, not a potency): 87%
Beside the measured number, compound 4's estimate is 1 percentage points below it; low and high end bracket the measured number.
By their numbers in this assay, from the lowest: compounds 1, 4, 2 and 3 (each within the scatter of the next).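

Within the data shown here, compound 4 brings chlorine onto the aryl group on the sulfonyl sulfur, where the earlier compounds carried only methoxy or methyl, and in this assay this change leaves the read-out within the scatter in all three comparisons: (a number 3 percentage points lower from compound 3 to compound 4 (within the scatter)), (a number 3 percentage points lower from compound 2 to compound 4 (within the scatter)) and (no change at the digits printed from compound 1 to compound 4 (within the scatter)). Phenyl, 3-methoxyphenyl, 3,4-dimethylphenyl and 3,5-dichlorophenyl on this sulfur therefore cannot be told apart by this read-out, and with this fourth aryl group the absence of a separation now extends to a chlorine-bearing ring. No supporting data are available to explain this result.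

The compounds shown leave open whether any group on the sulfonyl sulfur would move the read-out beyond the scatter, for instance a phenyl carrying a carboxylic acid or an amine, or a longer alkyl chain in place of the aryl ring. They also leave open whether these four compounds would separate in potency, as a read-out at one concentration gives the size of the inhibition at that concentration and not a potency.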